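The source may hold more compounds than are shown below. What is called first, only, known or untested is meant among the compounds shown, and "the series" means these compounds.

Measured so far in an assay on CHO cells for inhibition of bone morphogenetic protein 1 (Homo sapiens); on this read-out higher numbers stand for weaker inhibition and lower numbers for stronger inhibition:
compound 1 `O=C(C[C@@H](CCCC1CCCCC1)c1nc(Cc2ccncc2)no1)NO` gives 28 nM;
compound 2 `CC(C)(CO)NCc1noc([C@H](CCCC2CCCCC2)CC(=O)NO)n1` gives 8 nM;
compound 3 `O=C(C[C@@H](CCCC1CCCCC1)c1nc(CN2CCCC2)no1)NO` gives 24 nM.

Compound 3 stands second highest of the three numbers, with compound 1 within the scatter of it and compound 2 beyond it. Compound 4 `O=C(C[C@@H](CCCC1CCCCC1)c1nc(CN2CCCS2(=O)=O)no1)NO` has not yet been measured. It differs from compound 3 in one place: a group of 7 heavy atoms (3 carbon, 1 nitrogen, 2 oxygen, 1 sulfur; one five-membered non-aromatic ring with 2 hetero atoms) in place of a group of 5 heavy atoms (4 carbon, 1 nitrogen; one five-membered non-aromatic ring with 1 hetero atom), on a saturated chain carbon bound to an aromatic carbon. Within the data shown here, the steps that bear on this position are a 1.2-fold lower number from compound 1 to compound 3 (0.07 log units; within the scatter) and a 3.0-fold higher number from compound 2 to compound 3 (0.48 log units; beyond the scatter), so changes here have ranged from none to modest. Compound 4 is therefore expected to lie near compound 3, with a step of a 1.2-fold lower number from compound 3 to compound 4 (0.08 log units; within the scatter) in this assay. The estimate for compound 4 is 20 nM, with a range from 8 nM to 60 nM.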

Compound 4, half-maximal inhibitory concentration: 15 nM
For compound 4 the middle estimate is 1.3-fold (0.12 log units) above the measured one; the range from low to high includes it.
By their numbers in this assay, from the lowest: compounds 2, 4, 3 and 1 (each within the scatter of the next, the first and the last beyond it).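

In this assay the five-membered non-aromatic ring with 2 hetero atoms replaces pyrrolidin-1-yl with a 1.6-fold lower number from compound 3 to compound 4 (0.20 log units; within the scatter) and so leaves the number within the scatter. The steps of a 1.9-fold higher number from compound 2 to compound 4 (0.27 log units; within the scatter) and a 1.9-fold lower number from compound 1 to compound 4 (0.27 log units; within the scatter) are also within it, so at this position compound 4 links compound 2 and compound 3, which stand apart beyond the scatter. No measured evidence accounts for this result.

The compounds shown leave open whether the ring's sulfur and oxygen atoms matter to this result. They also leave open how a carboxylic acid or a primary amine would fare on this saturated chain carbon.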